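Compound 4: 3-bromophenyl in place of 4-methylphenyl

The compounds below may be only part of what the source reports. "The series", "measured", "known", "first", "only" and "open" are said of these compounds alone.

Among the compounds with values here, in a functional assay on MCF7 cells (Homo sapiens) for antiproliferative activity, read by sulforhodamine B assay, with a stated time of 48 h (on this read-out higher numbers stand for weaker inhibition and lower numbers for stronger inhibition), three compounds have values so far.
Compound 1 `O=C1NCCN1c1ccc(S(=O)(=O)Nc2ccc(C3CCCCC3)cc2)cc1` gives > 1000 nM as a limit of the assay
Compound 2 `Cc1ccc(NS(=O)(=O)c2ccc(N3CCNC3=O)cc2)cc1` gives 610 nM as a measured number
Compound 3 `CC(C)(C)c1ccc(NS(=O)(=O)c2ccc(N3CCNC3=O)cc2)cc1` gives > 1000 nM as a limit of the assay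

Within the data shown here, compound 2 holds the only true number in this set. What remains is the limit of > 1000 nM in this assay, at which 2 of the 3 values shown sit, and each of those two values is only a limit.

The next compound is compound 4 `O=C1NCCN1c1ccc(S(=O)(=O)Nc2cccc(Br)c2)cc1`, and the change is this: 3-bromophenyl in place of 4-methylphenyl on a sulfonamide nitrogen. In short, 3-bromophenyl stands in place of 4-methylphenyl on a sulfonamide nitrogen.

The measured steps that bear on it all change a group on an aromatic carbon. They are an at least 1.6-fold lower number from compound 1 to compound 2 (0.21 log units; that floor lies within the scatter) and an at least 1.6-fold higher number from compound 2 to compound 3 (0.21 log units; that floor lies within the scatter), along with a step that the two limits leave unreadable from compound 1 to compound 3. None of them swaps methyl for bromine, so they are only a loose guide. No step beyond the scatter is therefore expected in this assay, though a higher number is the likelier side, since an at least 1.6-fold higher number from compound 2 to compound 3 (0.21 log units; that floor lies within the scatter) ran that way.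

The estimate for compound 4 is 800 nM, with an expected range of 300 nM to 2000 nM as its ends. This estimate means an expected 1.3-fold higher number from compound 2 to compound 4 (0.12 log units; within the scatter) here.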

Compound 4, half-maximal inhibitory concentration: 100 nM
Compound 4: the middle estimate sits 8.0-fold (0.90 log units) above what was measured, and the stated range ends above it.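

In this assay, within the data shown here, the exchange on the sulfonamide nitrogen gives a 6.1-fold lower number from compound 2 to compound 4 (0.79 log units; beyond the scatter), and this is the first step in the set that has a readable size beyond the scatter. The earlier steps shown here all changed a group on an aromatic carbon, and with compound 1 and compound 3 held at limits, they gave only floors within the scatter or no readable size at all, so they did not show that this part of the molecule could move the read-out this far. The step also comes with no change in the counts of heavy atoms, hydrogen-bond donors or hydrogen-bond acceptors, so those counts do not track it in this pair, and 3-bromophenyl on the sulfonamide nitrogen is the best-placed group shown here.

Going by these compounds, this single change alters both the substituent and its place on the ring, so it remains open which of the two carries the step, and a chlorine or a methoxy group in place of the bromine would bear on the first. The set also offers few true numbers for comparison: the limit of > 1000 nM in this assay, at which 2 of the 4 values shown sit.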